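The source may hold more compounds than are shown below. What is called first, only, known or untested is meant among the compounds shown, and "the series" means these compounds.

Compound 1 `O[C@H](COCCOC[C@@H](O)Cc1cn(Cc2ccc3ccccc3c2)nn1)Cc1ccc(-c2ccccc2)cc1`: 8600 nM
Compound 2 `CC1=C(CCCCCCCCCCn2cc(C[C@H](O)COCCOC[C@@H](O)Cc3ccc(-c4ccccc4)cc3)nn2)C(=O)c2ccccc2C1=O`: 3000 nM
Compound 3 `COC1=C(OC)C(=O)C(CCCCCCCCCCn2cc(C[C@H](O)COCCOC[C@@H](O)Cc3ccc(-c4ccccc4)cc3)nn2)=C(C)C1=O`: 600 nM

Of the compounds shown here, three have been measured in a functional assay on HCT-116 cells (Homo sapiens) for inhibition, read by MTT assay, with a stated time of 72 h; on this read-out lower numbers stand for stronger inhibition of growth and higher numbers for weaker inhibition of growth. Compound 1 stands highest of the three numbers; in this assay compound 1 gives 8600 nM, whereas compound 2 gives 3000 nM and compound 3 gives 600 nM, both lower than compound 1 by margins beyond the usual scatter.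

Compound 4 `O=C1COc2ccc(-n3cc(C[C@H](O)COCCOC[C@@H](O)Cc4ccc(-c5ccccc5)cc4)nn3)cc2N1` has not yet been measured in this assay. It differs from compound 1 by a group of 11 heavy atoms (8 carbon, 1 nitrogen, 2 oxygen; one six-membered non-aromatic ring with 2 hetero atoms, one six-membered aromatic ring of carbon only) in place of a group of 11 heavy atoms (11 carbon; 2 six-membered aromatic rings of carbon only), on an aromatic nitrogen. Going by the values given here, no pair among the measured compounds shows this change, so no measured step guides the expectation directly; the only guidance is that compounds 2 and 3, which carry other groups in place of the naphthalenylmethyl, gave lower numbers than compound 1. On that basis a modest step down from compound 1 to compound 4 is expected, a 1.7-fold lower number from compound 1 to compound 4 (0.24 log units; within the scatter), though a change within the scatter cannot be excluded. For compound 4 the estimate in this assay is 5000 nM, with a range from 1200 nM to 20000 nM.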

Compound 4, concentration for 50% growth inhibition: 42500 nM
Estimate against measurement, compound 4: 8.5-fold (0.93 log units) below; measured number outside the range, above it.
By their numbers in this assay, from the lowest: compound 3; then compound 2; then compound 1; then compound 4.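

In this assay, the aromatic nitrogen proves sensitive to the nature of its group, not only to its heavy-atom count: replacing (naphthalen-2-yl)methyl with a group of equal count, carrying a six-membered non-aromatic ring with 2 hetero atoms, gives a 4.9-fold higher number from compound 1 to compound 4 (0.69 log units; beyond the scatter), a modest step beyond the scatter. Compound 4 is the first compound shown whose number stands above that of compound 1, so a change at this position can also weaken growth inhibition. No measurement shown here accounts for this step.

The compounds shown leave open which part of the entering group carries the step, since its non-aromatic ring and its hydrogen-bond donor and acceptors enter together. Going by these compounds, how a simple phenyl, an amine or a carboxylic acid on this nitrogen would read also remains open.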